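Hydroxyphenyl position change on the pyridinyl-bearing core

The compounds below may be only part of what the source reports. "The series", "measured", "known", "first", "only" and "open" are said of these compounds alone.

In a functional assay on HCT-15 cells (Homo sapiens) for cytotoxicity, read by CCK-8 assay (on this read-out higher numbers stand for weaker inhibition and lower numbers for stronger inhibition), compound 1 `Oc1ccc(-c2cc(-c3ccco3)cc(-c3cccc(O)c3)n2)cc1` gives 840 nM. Compound 2 `Oc1ccc(-c2cc(-c3cccnc3)cc(-c3ccccc3O)n2)cc1` reaches only the limit of the measurement, > 50000 nM, and no number is known for it (the limit of > 50000 nM in this assay, at which 1 of the 2 values shown sits). Compound 1 and compound 2 differ in two places at once, so their two values show only that one lies well inside the measurable range and the other beyond it. Compound 3 `Oc1ccc(-c2cc(-c3cccnc3)cc(-c3cccc(O)c3)n2)cc1` is the unmeasured member: 3-hydroxyphenyl in place of 2-hydroxyphenyl on an aromatic carbon, the two having the same atoms joined differently. Among the measured compounds shown here, no single-change step between measured compounds is available to set the size of this move. A step toward stronger inhibition, into the measurable range, is expected from compound 2 to compound 3, an at least 8.3-fold lower number from compound 2 to compound 3 (0.92 log units; beyond the scatter), with compound 1 at 840 nM as the only anchor for the 3-hydroxyphenyl. Compound 3 is expected at 6000 nM, within 900 nM to 50000 nM.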

Compound 3, half-maximal inhibitory concentration: > 50000 nM
Compound 3 gave a limit, no number; the forecaster's own chance of this, stated with the estimate: 30%; middle value at least 8.3-fold (0.92 log units) away from the limit.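

Among the compounds shown here, with the 3-hydroxyphenyl held constant, replacing furan-2-yl with pyridin-3-yl is the only readable single change in this assay, and it gives an at least 59-fold higher number from compound 1 to compound 3 (1.77 log units; beyond the scatter). The measurable value of compound 1 therefore does not carry over to the pyridin-3-yl series through the 3-hydroxyphenyl alone. The swap from 2-hydroxyphenyl to 3-hydroxyphenyl next to the ring nitrogen cannot be sized, as compound 2 and compound 3 both stand at a limit rather than a number: the limit of > 50000 nM in this assay, at which 2 of the 3 values shown sit.

Going by these compounds, whether the choice between 2-hydroxyphenyl and 3-hydroxyphenyl changes the value when furan-2-yl is present remains open. Also open, on these data alone, is whether thiophen-2-yl or an amine in place of furan-2-yl would keep the value within the measurable range.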